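Ethyl in Place of Hydrogen: Cytotoxicity Across Two Cores

The source may report more compounds than this note shows. Statements on the series, on what has been measured and on what is new or still open speak of the compounds shown alone.

Measured compounds:
compound 1, `COc1cccc2c(C(=O)/C=C(\O)C(=O)O)cn(Cc3ccc(F)cc3)c12`, 82900 nM
compound 2, `CCOC(=O)/C(O)=C/C(=O)c1cn(Cc2ccc(F)cc2)c2c(OC)cccc12`, > 100000 nM
compound 3, `COc1cccc2c1c(C(=O)/C=C(\O)C(=O)O)cn2Cc1ccc(F)cc1`, 41100 nM

The three compounds were tested in an ADME assay on MT4 cells (Homo sapiens) for cytotoxicity, read by MTT assay; on this read-out higher numbers stand for lower toxicity in this test and lower numbers for higher toxicity in this test. Compound 1 gives 82900 nM. For compound 2 the result of > 100000 nM is a limit of the assay, not a number. Compound 3 gives 41100 nM; its nearest neighbour among the measured numbers is compound 1, and the two lie within the usual scatter of each other, so no order between them is claimed. Compound 1 and compound 3 are built from the same atoms joined differently, and the difference between the two cores is not broken down here.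

Among the compounds with values here, the one measured step is an at least 1.2-fold higher number from compound 1 to compound 2 (0.08 log units; that floor lies within the scatter), the change being (ethyl in place of hydrogen on an oxygen next to a carbonyl group). The size of that step is open at its upper end due to the limit of > 100000 nM in this assay, at which 1 of the 3 values shown sits.

Compound 4, `CCOC(=O)/C(O)=C/C(=O)c1cn(Cc2ccc(F)cc2)c2cccc(OC)c12`, stands to compound 3 as compound 2 stands to compound 1: the change is ethyl in place of hydrogen on an oxygen next to a carbonyl group, the same change at the same place. The step is expected to be a 2.1-fold higher number from compound 3 to compound 4 (0.32 log units; beyond the scatter), resting on the earlier step of an at least 1.2-fold higher number from compound 1 to compound 2 (0.08 log units; that floor lies within the scatter) and on the value of compound 3, 41100 nM. Compound 4 is expected to give about 85000 nM, most likely between 40000 nM and 200000 nM.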

Compound 4, half-maximal cytotoxic concentration: 74000 nM
Estimate against measurement, compound 4: 1.1-fold (0.06 log units) above; the range from low to high includes it.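

In this assay, ethyl in place of hydrogen on an oxygen next to a carbonyl group gives a 1.8-fold higher number from compound 3 to compound 4 (0.26 log units; within the scatter), so on the core of compound 3 this change stays inside what repeated measurements would be expected to show. Set beside the earlier step, this result gives no sign that the change reads differently on the two cores, yet it does not show that the change carries over unaltered, and neither step can be called a real shift in this test: the same change on two cores in this assay, an at least 1.2-fold higher number (0.08 log units; that floor lies within the scatter) from compound 1 to compound 2 and a 1.8-fold higher number (0.26 log units; within the scatter) from compound 3 to compound 4; the limit leaves it open whether they differ. From the compounds shown here alone, the step on the core of compound 1 remains open at its upper end, and a larger step there cannot be ruled out, because compound 2 stands at a limit of the assay: the limit of > 100000 nM in this assay, at which 1 of the 4 values shown sits.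

The compounds shown hold only hydrogen or ethyl on this oxygen, so it remains open how a methyl group, a longer chain or an amide in place of the ester would read in this assay. With only two cores shown, it also remains open how ethyl in place of hydrogen would read on any further core.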